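Swapping phenyl for trifluoromethyl in a small urea series

The source may report more compounds than this note shows. Statements on the series, on what has been measured and on what is new or still open speak of the compounds shown alone.

- compound 1 `CCN1CCc2c(sc(NC(=O)Nc3ccc(Cl)cc3)c2C(N)=O)C1`: 3120 nM
- compound 2 `CCN1CCc2c(sc(NC(=O)Nc3ccc(I)cc3)c2C(N)=O)C1`: 1620 nM
- compound 3 `CCN1CCc2c(sc(NC(=O)Nc3ccc(-c4ccccc4)cc3)c2C(N)=O)C1`: 3390 nM

These numbers come from a functional assay (strain AB) with Danio rerio as the target, read by microscopy, with a stated time of 1 h; on this read-out lower numbers stand for an effect already at smaller amounts and higher numbers for an effect only at larger amounts of compound. Compound 3 sits at the upper end of this small set, a place it shares with another compound. The closest step is a 1.1-fold higher number from compound 1 to compound 3 (0.04 log units; within the scatter), and the furthest is a 2.1-fold higher number from compound 2 to compound 3 (0.32 log units; beyond the scatter).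

The next compound, compound 4 `CCN1CCc2c(sc(NC(=O)Nc3ccc(C(F)(F)F)cc3)c2C(N)=O)C1`, has trifluoromethyl in place of phenyl on an aromatic carbon. Among the compounds with values here, no trifluoromethyl compound has been measured yet, so the best guide is what the other swaps at this place did. Besides the two steps above, the data show a 1.9-fold lower number from compound 1 to compound 2 (0.28 log units; within the scatter). Within the data shown here, all three steps are small, and only the one from iodo to phenyl passes the scatter, and then only modestly. No step beyond the scatter is therefore expected in this assay, and no direction is favoured with any confidence. The estimated step is a 1.3-fold lower number from compound 3 to compound 4 (0.10 log units; within the scatter). For compound 4 the expected value is 2700 nM, with an estimated range from 1200 nM to 6000 nM.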

Compound 4, half-maximal effective concentration: 2910 nM
Estimate against measurement, compound 4: 1.1-fold (0.03 log units) below; measured number inside the range.
By their numbers in this assay, from the lowest: compounds 2, 4, 1 and 3 (each within the scatter of the next, the first and the last beyond it).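

Trifluoromethyl brings no ring, yet it takes the place of a six-membered aromatic ring with no readable change in this assay: the result is a 1.2-fold lower number from compound 3 to compound 4 (0.07 log units; within the scatter). Its steps from the two halogens tell the same story, with a 1.1-fold lower number from compound 1 to compound 4 (0.03 log units; within the scatter) and a 1.8-fold higher number from compound 2 to compound 4 (0.25 log units; within the scatter). Among chloro, iodo, phenyl and trifluoromethyl at this place, the only gap beyond the scatter remains the modest one between compound 2 and compound 3, and no information is available to explain why the numbers stay so close.

Still open, going by these compounds, is whether an amine, a carboxylic acid or a plain hydrogen at this place would move the number beyond the scatter. The shared core stays the same throughout, so these compounds also cannot tell whether the same swaps would behave alike on a different core.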